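Benzylselanyl for methylsulfanyl on a furan-bearing acyl amidine

The compounds below may be only part of what the source reports. "The series", "measured", "known", "first", "only" and "open" are said of these compounds alone.

Measured so far:
compound 1 `CS/C(=N\C(=O)c1ccco1)NC(=O)c1ccco1` with 56200 nM
compound 2 `O=C(/N=C(/NC(=O)c1cccs1)[Se]Cc1ccccc1)c1cccs1` with 49900 nM
compound 3 `CS/C(=N\C(=O)c1cccs1)NC(=O)c1cccs1` with 39000 nM

All three were tested in a functional assay on PC-3 cells (Homo sapiens) for cytotoxicity, read by MTT assay, with a stated time of 72 h; on this read-out lower numbers stand for stronger inhibition of growth and higher numbers for weaker inhibition of growth. In this assay compound 3 gives 39000 nM and compound 2 gives 49900 nM; the step between them, a 1.3-fold higher number from compound 3 to compound 2 (0.11 log units; within the scatter), came from the change (a group of 8 heavy atoms (7 carbon, 1 selenium; one six-membered aromatic ring of carbon only) in place of a group of 2 heavy atoms (1 carbon, 1 sulfur; no ring), on a carbon with a double bond to nitrogen). Compound 1 gives 56200 nM, and the difference between its core and that of compound 3 is not broken down here.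

Compound 4 `O=C(/N=C(/NC(=O)c1ccco1)[Se]Cc1ccccc1)c1ccco1` has not yet been measured. It arises from compound 1 by a group of 8 heavy atoms (7 carbon, 1 selenium; one six-membered aromatic ring of carbon only) in place of a group of 2 heavy atoms (1 carbon, 1 sulfur; no ring), on a carbon with a double bond to nitrogen, the same change that was made from compound 3 to compound 2, at the same place. Because that step was a 1.3-fold higher number from compound 3 to compound 2 (0.11 log units; within the scatter), the step from compound 1 to compound 4 is expected to be of a similar size, a 1.2-fold higher number from compound 1 to compound 4 (0.10 log units; within the scatter). Compound 4 is therefore estimated at 70000 nM, with a range from 35000 nM to 140000 nM.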

Compound 4, concentration for 50% growth inhibition: 30500 nM
For compound 4 the middle estimate is 2.3-fold (0.36 log units) above the measured one; the whole stated range lies above it.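

Swapping methylsulfanyl for benzylselanyl on the carbon with a double bond to nitrogen gives, in this assay, a 1.8-fold lower number from compound 1 to compound 4 (0.27 log units; within the scatter). Set beside the earlier step on the other core, the change reads the same on both cores once the usual scatter is allowed for: the same change on two cores in this assay, a 1.3-fold higher number (0.11 log units; within the scatter) from compound 3 to compound 2 and a 1.8-fold lower number (0.27 log units; within the scatter) from compound 1 to compound 4, 2.4-fold (0.37 log units) apart, within the scatter of two such steps. On these two cores, then, the change leaves growth inhibition within the scatter, but two small steps cannot show how it would behave on any other core.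

From the compounds shown here alone, the change also replaces sulfur with selenium and methyl with benzyl at once, so the part played by each stays open. Methylselanyl or benzylsulfanyl would separate the two, and an amine at the same carbon remains untested here as a different kind of group.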